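Cytotoxicity notes on a shared-core series, compound 4 pending

The source may hold more compounds than are shown below. What is called first, only, known or untested is meant among the compounds shown, and "the series" means these compounds.

Compound 1 `O=c1ccn(COC(CO)CO)c(=O)[nH]1` gives in a functional assay on HepG2 cells (Homo sapiens) for cytotoxicity (a lower number here means that less compound is tolerated, a higher number that more compound is tolerated), the limit > 462000 nM. Compound 2 `O=c1[nH]c(=O)n(COC(CO)CO)cc1[N+](=O)[O-]` gives in this assay the limit > 383000 nM. Compound 3 `CCc1cn(COC(CO)CO)c(=O)[nH]c1=O` gives in this assay the limit > 410000 nM.

Compound 3 therefore stands on a limit, and the two other values shown are limits as well; no number places it above or below either. The steps a step that the two limits leave unreadable from compound 1 to compound 2, a step that the two limits leave unreadable from compound 1 to compound 3 and a step that the two limits leave unreadable from compound 2 to compound 3 stay unreadable, since each rests on the limits (the limit of > 383000 nM in this assay, at which 1 of the 3 values shown sits), the limit of > 410000 nM in this assay, at which 1 of the 3 values shown sits, and (the limit of > 462000 nM in this assay, at which 1 of the 3 values shown sits).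

Compound 4 `O=c1[nH]c(=O)n(COC(CO)CO)cc1/C=C/Br` differs from compound 3 by 2-bromoethenyl in place of ethyl on an aromatic carbon. Among the compounds with values here, no measured step bears on this change with a readable size: all three changes on the same aromatic carbon left the read-out at a limit. For compound 4 the expectation is therefore that this assay again reports no step beyond the scatter, and the step of an at least 1.0-fold lower number from compound 3 to compound 4 (0.01 log units; that floor lies within the scatter) is estimated as within the scatter. Compound 4 is estimated at 400000 nM, with a range from 100000 nM to 1000000 nM.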

Compound 4, half-maximal cytotoxic concentration: > 311000 nM
Compound 4 was reported as a limit (the forecaster's own chance of this, stated with the estimate: 70%); the middle value lies beyond the limit too.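

In this assay compound 4 gives > 311000 nM, again a limit. Within the data shown here, no step between compound 4 and compound 1, compound 2 or compound 3 can be read. The compounds shown leave open at what concentration any of them becomes cytotoxic, and whether the group on the aromatic carbon changes that concentration.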